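A few compounds are considered here, and "the series" means these few. Any claim that something is new, unique, unknown or untested is made for them only; others in the source may bear on it.

The series rests on a shared core carrying two thiazolidinedione-bearing arms, varied at one aromatic position. Compound 1 (`COc1cc(-n2c(C)cc(/C=C3\SC(=O)NC3=O)c2C)ccc1-c1ccc(/C=C2\SC(=O)NC2=O)cc1`) gives in an assay for inhibition of glutaminase liver isoform, mitochondrial (Homo sapiens), read by coupled enzyme assay, with stated times of 10 min and 60 min (a lower number here means a stronger inhibitor, a higher number a weaker inhibitor), a value of 2140 nM. Compound 2 (`Cc1cc(/C=C2\SC(=O)NC2=O)c(C)n1-c1ccc(-c2ccc(/C=C3\SC(=O)NC3=O)cc2)c(O)c1`) differs from it by a hydrogen in place of the methyl on the oxygen of the aromatic ring, and in this assay compound 2 gives 5730 nM. Within the data shown here, the one measured step, a 2.7-fold higher number from compound 1 to compound 2 (0.43 log units; beyond the scatter), is modest but beyond the scatter. Among the measured compounds shown here, compound 2 therefore stands with the higher of the two numbers measured so far; its nearest neighbour is compound 1, with the lower number.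

Compound 3 (`Cc1cc(/C=C2\SC(=O)NC2=O)c(C)n1-c1ccc(-c2ccc(/C=C3\SC(=O)NC3=O)cc2)cc1`) follows from compound 2 by the change (hydrogen in place of hydroxy on an aromatic carbon). For the measured compounds named here, the only measured step that bears on this change is a 2.7-fold higher number from compound 1 to compound 2 (0.43 log units; beyond the scatter), which touched the same oxygen and moved the number by a modest amount. Taking away the oxygen altogether is a different alteration, so the expectation is a modest step, more likely downward toward the number of compound 1 than upward, or none beyond the scatter. Compound 3 is therefore expected at about 2800 nM, within a range from 1000 nM to 8000 nM, an estimated step of a 2.0-fold lower number from compound 2 to compound 3 (0.31 log units; beyond the scatter).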

Compound 3, half-maximal inhibitory concentration: 1190 nM
The estimate for compound 3 lay 2.4-fold (0.37 log units) above the measured number, within the range that was stated.
By their numbers in this assay, from the lowest: compounds 3 and 1 (each within the scatter of the next); then compound 2.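

Taken alone, the earlier pair could not show whether the oxygen at this position was of any benefit, since it compared only methoxy with hydroxy. In this assay, replacing the hydroxy with hydrogen gives a 4.8-fold lower number from compound 2 to compound 3 (0.68 log units; beyond the scatter), so the oxygen is not needed for the number seen with compound 1, and the methoxy shows no measurable gain over hydrogen: the comparison gives a 1.8-fold lower number from compound 1 to compound 3 (0.25 log units; within the scatter). Among these three compounds, then, only the hydroxy of compound 2 stands apart, with its steps to both of the others beyond the scatter, while methoxy and hydrogen cannot be told apart at this aromatic carbon; the data shown offer no explanation for this.

From the compounds shown here alone, it remains open how a fluorine, an amine or a carboxylic acid on this aromatic carbon would compare with the hydrogen of compound 3. Also open, going by these compounds, is whether a longer chain on the oxygen, such as ethoxy, would remain within the scatter of compound 3 as the methoxy of compound 1 does, or would move the number as the hydroxy does.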